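Removing the methylsulfonyl group from compound 2

The compounds below may be only part of what the source reports. "The series", "measured", "known", "first", "only" and "open" are said of these compounds alone.

Compound 2 `CS(=O)(=O)c1ccc(C(=O)Nc2ccc(Cl)c(-c3nnc4c(Cl)cccn34)c2)cc1` shares its core with compound 1 `O=C(Nc1ccc(Cl)c(-c2nnc3c(Cl)cccn23)c1)c1ccc(C(F)(F)F)cc1Cl` and compound 3 `CS(=O)(=O)c1ccc(C(=O)Nc2ccc(Cl)c(-c3nnc4c(Cl)cccn34)c2)c(Cl)c1`, and all three have been tested in a functional assay on MDA-MB-468 cells (Homo sapiens) for antiproliferative activity, read by MTT assay, with a stated time of 72 h; on this read-out higher numbers stand for weaker inhibition and lower numbers for stronger inhibition. In this assay compound 2 reaches only a limit, > 100000 nM. Compound 1 likewise gives a limit in this assay, > 100000 nM. Compound 3 also gives a limit in this assay, > 100000 nM. Because all three values sit at the limit of > 100000 nM in this assay, at which 3 of the 3 values shown sit, neither step that the two limits leave unreadable from compound 1 to compound 3 nor step that the two limits leave unreadable from compound 2 to compound 3 can be read in size or direction; the two measured steps therefore say nothing about how this assay responds to a change in the benzamide ring, beyond the fact that neither replacement brought a compound within the measurable range.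

Compound 4 `O=C(Nc1ccc(Cl)c(-c2nnc3c(Cl)cccn23)c1)c1ccccc1` differs from compound 2 in one place: hydrogen in place of methylsulfonyl on an aromatic carbon. For the measured compounds named here, no measured step covers this replacement. Since compound 2 stands at a limit, the expected step from compound 2 to compound 4 is a step that the limit leaves unreadable from compound 2 to compound 4, which is itself unreadable. For compound 4 the estimate in this assay is 150000 nM, within a range from 30000 nM to 600000 nM, with the most probable outcome being another limit.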

Compound 4, half-maximal inhibitory concentration: > 100000 nM
Compound 4 was reported as a limit; the forecaster's own chance of this, stated with the estimate: 80%; the middle value lies beyond the limit too.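

Compound 2 and compound 4 both stand at a limit, so the step between them cannot be read in size or direction in this assay: the limit of > 100000 nM in this assay, at which 4 of the 4 values shown sit.

The compounds shown leave open whether any change to the benzamide ring on this shared core would give a measurable value in this assay.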